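The source may report more compounds than this note shows. Statements on the series, on what has been measured and on what is new or still open speak of the compounds shown alone.

Compound 1 `C=CCn1c(=O)c2[nH]cnc2n(CCC)c1=O` in an assay on Cerebral cortex for binding affinity to adenosine receptor A1 (Cavia porcellus), read by radioligand binding (on this read-out higher numbers stand for weaker inhibition and lower numbers for stronger inhibition), gives 1700 nM. Compound 2 `CCCn1c(=O)n(CC(=O)O)c(=O)c2[nH]cnc21` in this assay reaches only > 200000 nM, which is a limit of the assay and not a number. Compound 3 `CCCn1c(=O)n(CCOC)c(=O)c2[nH]cnc21` in this assay gives 2500 nM.

Of the two numbers shown, compound 3 sits beside compound 1: the step of a 1.5-fold higher number from compound 1 to compound 3 (0.17 log units; within the scatter) lies within the scatter, so the two are not told apart. Compound 2 stands apart; its value is only a limit (the limit of > 200000 nM in this assay, at which 1 of the 3 values shown sits), and the step of an at least 80-fold lower number from compound 2 to compound 3 (1.90 log units; beyond the scatter) is large, as is the step of an at least 110-fold higher number from compound 1 to compound 2 (2.07 log units; beyond the scatter).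

Compound 4 `CCCn1c(=O)n(CC(C)=O)c(=O)c2[nH]cnc21` has not yet been measured. It differs from compound 3 in one place: acetyl in place of methoxymethyl on a saturated chain carbon bound to an aromatic nitrogen. Both the group that leaves and the group that enters are small, neutral, and carry one hydrogen-bond acceptor. Going by the values given here, the only large step seen so far involves the carboxy group of compound 2, which does not enter here. Among the compounds with values here, the steps that bear on this change are therefore a 1.5-fold higher number from compound 1 to compound 3 (0.17 log units; within the scatter), small, and the large ones involving compound 2 that set a warning on the carboxy side only. The step from compound 3 to compound 4 is expected to be modest, a 1.6-fold higher number from compound 3 to compound 4 (0.20 log units; within the scatter), likely within the scatter or slightly toward a higher number. Compound 4 is estimated at 4000 nM, with a range from 1500 nM to 15000 nM.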

Compound 4, inhibition constant: 11400 nM
Compound 4: the middle estimate sits 2.9-fold (0.45 log units) below what was measured; the measured number falls inside the stated range.
By their numbers in this assay, from the lowest: compounds 1 and 3 (each within the scatter of the next); then compound 4. At a limit, above all of these: compound 2.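

In this assay, the step of a 4.6-fold higher number from compound 3 to compound 4 (0.66 log units; beyond the scatter) and the step of a 6.7-fold higher number from compound 1 to compound 4 (0.83 log units; beyond the scatter) both lie beyond the scatter, so this place, on a saturated chain carbon bound to an aromatic nitrogen, also separates neutral groups, even though acetyl and methoxymethyl match in heavy atoms, hydrogen-bond donors and hydrogen-bond acceptors. Carboxy is therefore no longer the only group that shifts the number here, though the largest shift still belongs to it: with the carbonyl kept and methyl in place of hydroxy, the result is an at least 17-fold lower number from compound 2 to compound 4 (1.24 log units; beyond the scatter), so a carbonyl alone does not carry the whole of what separates compound 2 from the others. The value of compound 2 is a limit and not a number, so that step gives only a lower bound on the size of the gap: the limit of > 200000 nM in this assay, at which 1 of the 4 values shown sits.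

The compounds shown do not settle whether the higher number of compound 4 belongs to the carbonyl itself or to the acetyl group as a whole, and a primary amide, which also holds a carbonyl, could test this. From the compounds shown here alone, how an amine or a longer chain in the same place would read also remains open.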